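The compounds below may be only part of what the source reports. "The series", "measured", "known", "first", "only" and "open" are said of these compounds alone.

Measured so far, in an assay on brain for binding affinity to Neuronal acetylcholine receptor; alpha4/beta2 (Rattus norvegicus), read by radioligand binding; on this read-out higher numbers stand for weaker inhibition and lower numbers for stronger inhibition:
compound 1 `Fc1ccc(OC[C@@H]2CCN2)cn1` gives 0.057 nM;
compound 2 `Cc1ccc(OC[C@@H]2CCN2)cn1` gives 0.057 nM;
compound 3 `C=Cc1ccc(OC[C@@H]2CCN2)cn1` gives 1.25 nM.

Compound 3 stands at the highest number of the three, with compound 1 and compound 2 both well below it. Compound 4 `c1ccc(-c2ccc(OC[C@@H]3CCN3)cn2)cc1` differs from compound 3 in one place: phenyl in place of vinyl on an aromatic carbon. Going by the values given here, two measured steps bear on this: a 22-fold higher number from compound 1 to compound 3 (1.34 log units; beyond the scatter) and a 22-fold higher number from compound 2 to compound 3 (1.34 log units; beyond the scatter), both showing that vinyl at this aromatic carbon weakened binding sharply compared with fluoro or methyl, while no change at the digits printed from compound 1 to compound 2 (within the scatter) showed that the small groups were interchangeable. Phenyl is a larger group than vinyl, so a further rise in this assay is expected, estimated as a 9.6-fold higher number from compound 3 to compound 4 (0.98 log units; beyond the scatter). Compound 4 is therefore expected to give about 12 nM, within a range of 2.5 nM to 60 nM.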

Compound 4, inhibition constant: 2.3 nM
Compound 4: the middle estimate sits 5.2-fold (0.72 log units) above what was measured; measured number below the stated range.
By their numbers in this assay, from the lowest: compounds 1 and 2 (each within the scatter of the next); then compounds 3 and 4 (each within the scatter of the next).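

Phenyl on this aromatic carbon reads in this assay as a 1.8-fold higher number from compound 3 to compound 4 (0.26 log units; within the scatter), so going from vinyl to a group of 6 heavy atoms with its own aromatic ring brings no rise that stands out from the scatter. The gap to the small groups stays large, with a 40-fold higher number from compound 2 to compound 4 (1.61 log units; beyond the scatter) and a 40-fold higher number from compound 1 to compound 4 (1.61 log units; beyond the scatter), which places both vinyl and phenyl well apart from methyl and fluoro. Nothing measured here explains why these two groups read alike.

Still open, on these data alone, is where ethyl, the saturated counterpart of vinyl, would fall, with the small groups or with vinyl and phenyl. An amine or a carboxylic acid at this carbon also remains an open case.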